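Phenyl in place of naphthalen-1-yl in a growth-inhibition series

This account rests on a few compounds, and the source may have more. Where it says the series, first, only, none or still open, it means among the compounds named here.

Compound 1 `COc1cc(/C=C/C(=O)/C=C/c2cccc3ccccc23)ccc1OCc1cn(CCCCOc2cc(=O)oc3ccccc23)nn1` was tested in a functional assay on PC-3 cells (Homo sapiens) for inhibition, read by sulforhodamine B assay, with a stated time of 48 h, tested at 50 uM (a higher number here means more inhibition of growth at the concentration tested, a lower number less inhibition of growth), and is recorded there only as "not active" (no number reported); no single number marks where it stands in this assay, only the statement that growth was not inhibited to a reportable degree. Compound 2 `COc1cc(/C=C/C(=O)/C=C/c2ccccc2)ccc1OCc1cn(CCOc2cc(=O)oc3ccccc23)nn1`, a close relative from the same set, gives 10% in this assay, a low reading that sits within the usual scatter of such measurements.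

Compound 3 `COc1cc(/C=C/C(=O)/C=C/c2ccccc2)ccc1OCc1cn(CCCCOc2cc(=O)oc3ccccc23)nn1` differs from compound 1 in one place: phenyl in place of naphthalen-1-yl on a double-bonded chain carbon bound to a double-bonded chain carbon. Among the measured compounds shown here, no measured pair in this set carries exactly this change, so its size cannot be read from the numbers at hand. The account therefore rests on what is known: compound 1 is reported as not active, and compound 2, which also carries phenyl on the chain, gives 10%. The expected step from compound 1 to compound 3 in this assay is thus none beyond the scatter, in either direction. Compound 3 is accordingly estimated at 8%, with a range from 0% to 22%, and a real chance that only a statement of no activity is reported.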

Compound 3, percent growth inhibition at one concentration: "not active" (no number reported)
Compound 3 has no reported number here; the estimate stays without a comparison.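

In this assay, among the compounds shown here, compound 1 gives "not active" (no number reported) and compound 3 gives "not active" (no number reported) with no number for either, so no step between them can be read. The compounds shown leave open whether phenyl in place of naphthalen-1-yl changes growth inhibition at all. No evidence at hand bears on these two results.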